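Side-chain change at the amino acid part of compound 3

This account rests on a few compounds, and the source may have more. Where it says the series, first, only, none or still open, it means among the compounds named here.

Compound 3 `C[C@@H](O)[C@H](NC(=O)CN(c1nc(Cl)nc2[nH]cnc12)C1CC1)C(=O)O` is the reference point. In a functional assay on the whole organism (Tail, strain ICR) with Mus musculus as the target, in the tail flick test, with a stated time of 150 min, at a dose of 25 umol/kg by the oral route (on this read-out lower numbers stand for a weaker effect and higher numbers for a stronger effect at the one dose given), compound 3 gives 24%, the highest of the three numbers in hand. Compound 2 `C[C@@H](O)[C@H](NC(=O)CN(c1nc(Cl)nc2[nH]cnc12)C1CC1)C(=O)OCc1ccccc1` gives 12.8% and compound 1 `O=C(O)[C@@H]1CCCN1C(=O)CN(c1nc(Cl)nc2[nH]cnc12)C1CC1` gives 7.29%. The two steps that reach compound 3 are both modest: a number 16.7 percentage points higher from compound 1 to compound 3 (beyond the scatter) and a number 11.2 percentage points higher from compound 2 to compound 3 (beyond the scatter). Both alter the amino acid part of the molecule, as does the step to compound 4 `NC(=O)CC[C@H](NC(=O)CN(c1nc(Cl)nc2[nH]cnc12)C1CC1)C(=O)O`: 2-carbamoylethyl in place of 1-hydroxyethyl on a saturated chain carbon bound to an amide-type nitrogen and a carbonyl carbon. For the measured compounds named here, no measured step touches this particular side chain, so the two known steps set only the scale; a step of their size in either direction, or none beyond the scatter, is plausible. A small drop is expected, a number 6 percentage points lower from compound 3 to compound 4 (within the scatter). Compound 4 is estimated at 18%, with a range from 5% to 35%.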

Compound 4, a percentage reported as activity, at one dose (the size of the read-out at that dose, not a potency): 11.4%
Compound 4: middle estimate off by 6.6 percentage points, on the high side, within the range that was stated.
By their numbers in this assay, from the lowest: compounds 1, 4 and 2 (each within the scatter of the next); then compound 3.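

In this assay, the side chain on the saturated chain carbon bound to an amide-type nitrogen and a carbonyl carbon proves to count: a number 12.6 percentage points lower from compound 3 to compound 4 (beyond the scatter). For the compounds shown here, this is the first reading at this side chain itself, and 2-carbamoylethyl does not stand in for 1-hydroxyethyl without loss. Nothing at hand accounts for the drop.

Going by these compounds, the step replaces chain and end group together, and which of the two carries the difference stays open. Also open, on these data alone, is a side chain bearing an amine or a carboxylic acid, or a plain longer chain.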